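Cycloheptyl in Place of Dichlorophenyl on Compound 1

This account rests on a few compounds, and the source may have more. Where it says the series, first, only, none or still open, it means among the compounds named here.

Measured so far:
- compound 1 `Nc1scc(CN2CCN(c3cccc(Cl)c3Cl)CC2)c1C(=O)c1ccc(Cl)cc1`: 3.2%
- compound 2 `Nc1scc(CN2CCN(c3ccccc3C(F)(F)F)CC2)c1C(=O)c1ccc(Cl)cc1`: -7.5%
- compound 3 `Nc1scc(CN2CCN(c3ccc(Cl)c(C(F)(F)F)c3)CC2)c1C(=O)c1ccc(Cl)cc1`: -12%

All three were tested in a functional assay on CHO cells with adenosine receptor A1 (Homo sapiens) as the target, read by cAMP accumulation and immunoassay, with a stated time of 6 min, tested at 0.1 uM; a higher number here means a weaker effect of the compound at the concentration tested, a lower number a stronger effect. Compound 1 gives the highest of the three numbers; the nearest is compound 2, the furthest compound 3. The step of a number 10.7 percentage points lower from compound 1 to compound 2 (beyond the scatter) and the step of a number 15.2 percentage points lower from compound 1 to compound 3 (beyond the scatter) both lower the number, each beyond the usual scatter but only modestly, while the step of a number 4.5 percentage points lower from compound 2 to compound 3 (within the scatter) stays within the scatter.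

The new compound 4 `Nc1scc(CN2CCN(C3CCCCCC3)CC2)c1C(=O)c1ccc(Cl)cc1` differs from compound 1 in one place: cycloheptyl in place of 2,3-dichlorophenyl on an amine nitrogen in a ring. Among the compounds with values here, none of the measured steps exchanges an aromatic ring for a saturated one, so they bear on this change only loosely; what they show is that swapping the group on that ring nitrogen has so far moved the read-out by small amounts downward. A similar modest downward step is therefore expected, a number 8.2 percentage points lower from compound 1 to compound 4 (within the scatter). Compound 4 is accordingly estimated at -5%, with a range from -20% to 10%.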

Compound 4, a percentage reported as activity, at one concentration (the size of the read-out at that concentration, not a potency): 13%
For compound 4 the middle estimate is 18 percentage points below the measured one; measured number outside the range, above it.
By their numbers in this assay, from the lowest: compounds 3 and 2 (each within the scatter of the next); then compounds 1 and 4 (each within the scatter of the next).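

Cycloheptyl is the first saturated ring on this ring nitrogen, and in place of 2,3-dichlorophenyl it gives a number 9.8 percentage points higher from compound 1 to compound 4 (within the scatter) in this assay, so at this position a saturated carbon ring cannot be told apart from that aromatic ring. The other two aromatic groups give a clearer contrast, with a number 25 percentage points higher from compound 3 to compound 4 (beyond the scatter) and a number 20.5 percentage points higher from compound 2 to compound 4 (beyond the scatter), both modest. Within the data shown here, these are the first steps beyond the scatter that raise the number at this position, whereas the earlier ones beyond the scatter lowered it.

Nothing measured here gives a reason for this difference. Still open, as far as these compounds go, is how the read-out responds to ring size and shape, as with cyclopentyl or cyclohexyl, or to an open chain such as n-hexyl on the same nitrogen.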